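A few compounds are considered here, and "the series" means these few. Any claim that something is new, unique, unknown or untested is made for them only; others in the source may bear on it.

Compound 3 `CC(C)S(=O)(=O)CCC12CCC(c3nnc(-c4ccccc4C(F)(F)F)n3C)(CC1)CC2` holds the highest of three numbers in a functional assay on the whole organism (strain ICR) for inhibition, with Mus musculus as the target, with a stated time of 4 h, at a dose of 10 mg/kg by the oral route (a higher number here means more inhibition at the dose given (going by the name of the read-out), a lower number less inhibition), where compound 3 gives 88%; compound 1 `CCS(=O)(=O)CCC12CCC(c3nnc(-c4ccccc4C)n3C)(CC1)CC2` gives 86% and compound 2 `CCS(=O)(=O)CCC12CCC(c3nnc(-c4ccccc4Br)n3C)(CC1)CC2` gives 86%, both within the scatter of compound 3. For the measured compounds named here, the one measured step, no change at the digits printed from compound 1 to compound 2 (within the scatter), concerns a substituent on an aromatic carbon, not the chain. Compound 4 `CCOCC12CCC(c3nnc(-c4ccccc4C(F)(F)F)n3C)(CC1)CC2` differs from compound 3 by ethoxy in place of (isopropylsulfonyl)methyl on a saturated chain carbon bound to a saturated ring carbon. Going by the values given here, no measured step bears on this change, so the size and direction of the step of a number 10 percentage points lower from compound 3 to compound 4 (within the scatter) expected from it are uncertain, a loss being as plausible as no change beyond the scatter. Compound 4 is therefore estimated to give 78% in this assay, within a range from 50% to 95%.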

Compound 4, a percentage reported as inhibition, in the whole organism at one dose (the size of the read-out at that dose, not a potency): 44%
For compound 4 the middle estimate is 34 percentage points above the measured one; measured number below the stated range.
By their numbers in this assay, from the lowest: compound 4; then compounds 1, 2 and 3 (each within the scatter of the next).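

Replacing (isopropylsulfonyl)methyl with ethoxy on a saturated chain carbon bound to a saturated ring carbon gives a number 44 percentage points lower from compound 3 to compound 4 (beyond the scatter) in this assay. For the compounds shown here, this shows that the number depends on this chain, whereas the one earlier step concerned only a substituent on an aromatic carbon. Nothing measured here explains the fall. The change both removes the sulfonyl group and shortens the chain, and the compounds shown do not separate these two differences. From the compounds shown here alone, how an amine, a carboxylic acid or a longer ether chain would fare at this place remains open.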